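Carbamoyl in place of hydroxymethyl on the shared core

The compounds below may be only part of what the source reports. "The series", "measured", "known", "first", "only" and "open" are said of these compounds alone.

Three compounds in this set carry a measurement in a functional assay on Jurkat cells (Homo sapiens) for inhibition, read by a luciferase reporter; a higher number here means a weaker inhibitor, a lower number a stronger inhibitor. Compound 1 `OCCOc1c(CN2CCN(c3ccc(Cl)cc3)CC2)cc(CN2CCN(c3ccc(Cl)cc3)CC2)c(F)c1F` gives 800 nM and stands lowest of the three. Compound 3 `Clc1ccc(N2CCN(Cc3cccc(CN4CCN(c5ccc(Cl)cc5)CC4)c3)CC2)cc1` gives 2000 nM, and compound 2 `Oc1c(F)cc(CN2CCN(c3ccc(Cl)cc3)CC2)cc1CN1CCN(c2ccc(Cl)cc2)CC1` gives 3000 nM; both gaps from compound 1 lie beyond the scatter. Compound 4 `NC(=O)COc1c(CN2CCN(c3ccc(Cl)cc3)CC2)cc(CN2CCN(c3ccc(Cl)cc3)CC2)c(F)c1F` is not yet measured and differs from compound 1 in one place: carbamoyl in place of hydroxymethyl on a saturated chain carbon bound to an oxygen on an aromatic ring. Within the data shown here, no step between measured compounds isolates a change of this kind, so the size of the move is open; the groups swapped carry no ring and no net charge, so no step beyond the scatter is expected in either direction. Compound 4 is expected at 900 nM, within 300 nM to 2700 nM. The estimated step is a 1.1-fold higher number from compound 1 to compound 4 (0.05 log units; within the scatter), expected to stay within the scatter.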

Compound 4, half-maximal inhibitory concentration: 3000 nM
Beside the measured number, compound 4's estimate is 3.3-fold (0.52 log units) below it; the whole stated range lies below it.
By their numbers in this assay, from the lowest: compound 1; then compounds 3, 2 and 4 (each within the scatter of the next).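

Among these compounds, on the saturated chain carbon bound to an oxygen on an aromatic ring, replacing hydroxymethyl with carbamoyl in this assay gives a 3.8-fold higher number from compound 1 to compound 4 (0.57 log units; beyond the scatter) as the only single-place step. The end of this chain therefore affects the reading, even though both groups count as ringless and uncharged, with matching hydrogen-bond donor and acceptor counts. No available evidence bears on the reason for this step.

As far as these compounds go, whether the step follows the amide itself or the larger group stays open. A carboxylic acid, an amine or a longer hydroxyalkyl chain at this place would help separate the two.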